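The source may hold more compounds than are shown below. What is called first, only, known or untested is meant among the compounds shown, and "the series" means these compounds.

Compound 3 `COC(=O)C[C@@H](NC(=O)Cn1cc(C2=C(c3c[nH]c4ccccc34)C(=O)N(C)C2=O)c2ccccc21)C(=O)OC` is built on the shared core with an amide-linked side chain that carries two methoxycarbonyl groups. In a functional assay on A2780 cells (Homo sapiens) for cytotoxicity, read by MTT assay, with a stated time of 24 h (a lower number here means a stronger inhibitor, a higher number a weaker inhibitor), compound 3 gives 15400 nM, the lowest of the two numbers available here. Compound 1 `COC(=O)CCNC(=O)Cn1cc(C2=C(c3c[nH]c4ccccc34)C(=O)N(C)C2=O)c2ccccc21` is the closest neighbour of compound 3, and in this assay compound 1 gives 44500 nM, so the step reads a 2.9-fold lower number from compound 1 to compound 3 (0.46 log units; beyond the scatter). Compound 2 `CC[C@H](C)[C@@H](NC(=O)Cn1cc(C2=C(c3c[nH]c4ccccc34)C(=O)N(C)C2=O)c2ccccc21)C(=O)OC` gives > 100000 nM in this assay, which is a limit of the assay rather than a number (the limit of > 100000 nM in this assay, at which 1 of the 3 values shown sits). From compound 2 the step reads an at least 6.4-fold lower number from compound 2 to compound 3 (0.81 log units; beyond the scatter).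

Compound 4 `COC(=O)CC[C@@H](NC(=O)Cn1cc(C2=C(c3c[nH]c4ccccc34)C(=O)N(C)C2=O)c2ccccc21)C(=O)OC` has not yet been tested. Its change from compound 3 is (methoxycarbonyl)methyl in place of methoxycarbonyl on a saturated chain carbon, two bonds along the chain from an amide-type nitrogen and a carbonyl carbon. Neither measured step lengthens a chain by one carbon: the step from compound 1 adds the group outright, the step from compound 2 exchanges one group for another, and both shifted the number only to a modest degree. The expectation is therefore a small step, if any, reading a 1.3-fold higher number from compound 3 to compound 4 (0.11 log units; within the scatter) in this assay. Compound 4 is estimated to give 20000 nM, within an expected range from 8000 nM to 50000 nM.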

Compound 4, half-maximal inhibitory concentration: 32300 nM
Compound 4: the middle estimate sits 1.6-fold (0.21 log units) below what was measured, and the stated range covers the measured number.
By their numbers in this assay, from the lowest: compound 3; then compounds 4 and 1 (each within the scatter of the next). At a limit, above all of these: compound 2.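

Lengthening the ester arm by one carbon at this saturated chain carbon, with (methoxycarbonyl)methyl replaced by 2-(methoxycarbonyl)ethyl, is not a silent change in this assay: the step reads a 2.1-fold higher number from compound 3 to compound 4 (0.32 log units; beyond the scatter), so the length of this arm matters as well as the presence of the ester. Going by these compounds alone, with the longer arm, the second ester group no longer sets the compound clearly apart from the side chain with a single ester, as the step reads a 1.4-fold lower number from compound 1 to compound 4 (0.14 log units; within the scatter), whereas the shorter arm of compound 3 did stand apart from compound 1. With 2-(methoxycarbonyl)ethyl in place of sec-butyl the step reads an at least 3.0-fold lower number from compound 2 to compound 4 (0.49 log units; beyond the scatter), and its size is only a bound, because compound 2 stands at a limit of the assay and not at a number: the limit of > 100000 nM in this assay, at which 1 of the 4 values shown sits.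

Only this one lengthening is shown, so it remains open whether a still longer chain carrying the ester would continue the same drift. On these data alone, it also remains open how a free carboxylic acid or an amine at the end of this arm would read in this assay.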